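A Carbonyl Enters Compound 2

A few compounds are considered here, and "the series" means these few. Any claim that something is new, unique, unknown or untested is made for them only; others in the source may bear on it.

Compound 1 `O=C(NNc1ccc(F)cc1)c1ccc(NS(=O)(=O)c2cnc(O)nc2O)cc1`: > 20000 nM (a limit)
Compound 2 `O=C(NNc1cccc(Cl)c1)c1cccc(NS(=O)(=O)c2cnc(O)nc2O)c1`: 6640 nM

Among the measured compounds shown here, in a functional assay on A549 cells (Homo sapiens) for antiproliferative activity, read by MTT assay, with a stated time of 24 h (on this read-out higher numbers stand for weaker inhibition and lower numbers for stronger inhibition), compound 2 gives 6640 nM, the only actual number so far. The entry for compound 1 is a limit of the assay, > 20000 nM. Compound 3 `O=C(NNC(=O)c1cccc(NS(=O)(=O)c2cnc(O)nc2O)c1)c1cccc(Cl)c1` carries (3-chlorophenyl)carbonyl in place of 3-chlorophenyl on an amine nitrogen. For the measured compounds named here, no measured step offers a guide, so only a modest shift towards weaker inhibition in this assay is expected, an estimated 1.4-fold higher number from compound 2 to compound 3 (0.13 log units; within the scatter). Compound 3 is estimated at 9000 nM, with an expected range of 3000 nM to 27000 nM.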

Compound 3, half-maximal inhibitory concentration: 6000 nM
Beside the measured number, compound 3's estimate is 1.5-fold (0.18 log units) above it, and the stated range covers the measured number.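

Placing (3-chlorophenyl)carbonyl in place of 3-chlorophenyl on an amine nitrogen gives a 1.1-fold lower number from compound 2 to compound 3 (0.04 log units; within the scatter) in this assay, so at this position the added carbonyl leaves the number unchanged within the scatter. Among the compounds shown here, this is the first measured step at this position, as no earlier pair of compounds differed in one place. Nothing measured here accounts for the size of this step.

Still open, as far as these compounds go, is whether an acetyl group or a longer alkyl chain on this nitrogen would move the number beyond the scatter. From the compounds shown here alone, whether an amine in place of the chlorine would do so is also open.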